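The compounds below may be only part of what the source reports. "The series", "measured", "known", "first", "only" and "open" are said of these compounds alone.

Compound 1 `CCCCOC1=C(C(=O)c2ccccc2)C(c2ccc(Br)cc2)N(CCCn2ccnc2)C1=O` is the reference point of this small series. In a functional assay on NCI-H1299 cells (Homo sapiens) for antiproliferative activity, read by MTT assay, with a stated time of 72 h (on this read-out higher numbers stand for weaker inhibition and lower numbers for stronger inhibition), compound 1 gives 17100 nM, the lowest of the three numbers measured. Its nearest neighbour is compound 3 `CCOc1ccc(NC2=C(C(=O)c3ccccc3)C(c3ccc(Br)cc3)N(CCCn3ccnc3)C2=O)cc1`, which gives 20000 nM; the step between them is a 1.2-fold higher number from compound 1 to compound 3 (0.07 log units; within the scatter). Its furthest neighbour is compound 2 `NC1=C(C(=O)c2ccccc2)C(c2ccc(Br)cc2)N(CCCn2ccnc2)C1=O`, which gives 169000 nM; that step is a 9.9-fold higher number from compound 1 to compound 2 (0.99 log units; beyond the scatter). From compound 2 to compound 3 the direction reverses, with an 8.5-fold lower number from compound 2 to compound 3 (0.93 log units; beyond the scatter).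

Compound 4 `O=C(C1=C(Nc2ccc(Br)cc2)C(=O)N(CCCn2ccnc2)C1c1ccc(Br)cc1)c1ccccc1` differs from compound 1 in one place: (4-bromophenyl)amino in place of butoxy on a double-bonded ring carbon. The step that bears most directly on this change is a 1.2-fold higher number from compound 1 to compound 3 (0.07 log units; within the scatter), which also exchanged butoxy for an arylamino group on the double-bonded ring carbon and stayed within the scatter. The step of an 8.5-fold lower number from compound 2 to compound 3 (0.93 log units; beyond the scatter) points the same way: an aryl group on the amine nitrogen keeps the number low. The expectation for compound 4 is therefore a step of a 1.2-fold higher number from compound 1 to compound 4 (0.07 log units; within the scatter), nothing beyond the scatter. The estimated value for compound 4 is 20000 nM, with a range from 7000 nM to 60000 nM.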

Compound 4, half-maximal inhibitory concentration: 19300 nM
The estimate for compound 4 lay 1.0-fold (0.02 log units) above the measured number, within the range that was stated.
By their numbers in this assay, from the lowest: compounds 1, 4 and 3 (each within the scatter of the next); then compound 2.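

In this assay, a second arylamino group behaves like the first: the step of a 1.1-fold higher number from compound 1 to compound 4 (0.05 log units; within the scatter) stays within the scatter, and so does the exchange of bromo for ethoxy on the aromatic carbon, a 1.0-fold lower number from compound 3 to compound 4 (0.02 log units; within the scatter). Placing 4-bromophenyl on the amine nitrogen repeats the gain seen with 4-ethoxyphenyl, an 8.8-fold lower number from compound 2 to compound 4 (0.94 log units; beyond the scatter), so among these four compounds only the bare amino group of compound 2 stands apart. No measurement is available that would explain these results.

The compounds shown leave open whether the aromatic ring on the amine nitrogen is itself needed, since a butylamino group would separate the ring from the chain length. They also leave open whether phenylamino without a substituent, or a carboxylic acid on that ring, would stay level with compound 1.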